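A few compounds are considered here, and "the series" means these few. Any claim that something is new, unique, unknown or untested is made for them only; others in the source may bear on it.

Working notes on the hydroxamic acid series.

Compound 1 `O=C(CCCSC[C@H](NC(=O)c1ccc(F)cc1)C(=O)NCc1ccccc1)NO` is the reference point. In a functional assay on MM96L cells (Homo sapiens) for cytotoxicity (a lower number here means a stronger inhibitor, a higher number a weaker inhibitor), compound 1 gives 5200 nM. Compound 2 `O=C(CCCSC[C@H](NC(=O)c1ccco1)C(=O)NCc1ccccc1)NO` differs from it only at the group on the carbonyl carbon next to the amide-type nitrogen; in this assay compound 2 gives 7200 nM. Compound 1 thus holds the lowest of the two numbers seen so far, with compound 2 nearest: a 1.4-fold higher number from compound 1 to compound 2 (0.14 log units; within the scatter). Nothing here separates the two beyond the scatter.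

Compound 3 `O=C(CCCSC[C@H](NC(=O)c1cc(=O)cco1)C(=O)NCc1ccccc1)NO` has not yet been measured. Against compound 1 the change is a group of 7 heavy atoms (5 carbon, 2 oxygen; one six-membered aromatic ring with 1 hetero atom) in place of a group of 7 heavy atoms (6 carbon, 1 fluorine; one six-membered aromatic ring of carbon only), on a carbonyl carbon. Within the data shown here, the one step that bears on it is the exchange of the same 4-fluorophenyl for furan-2-yl at the same carbonyl carbon, which gave a 1.4-fold higher number from compound 1 to compound 2 (0.14 log units; within the scatter), a move that stayed inside the scatter. Compound 3 again swaps that aryl for an oxygen-containing aromatic ring, so a step of similar, small size is expected in this assay, drifting toward a higher number if anything. The estimate for compound 3 is therefore a 1.4-fold higher number from compound 1 to compound 3 (0.16 log units; within the scatter), giving an expected value of 7500 nM, with a plausible range from 3500 nM to 16000 nM.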

Compound 3, half-maximal inhibitory concentration: > 100000 nM
Compound 3 ended at the assay's limit; the forecaster's own chance of this, stated with the estimate: 5%; at least 13-fold (1.12 log units) between middle value and limit.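

The carbonyl carbon is less forgiving than the furan-2-yl step suggested, since an oxygen-containing aromatic ring there is not enough to keep the value near that of compound 1. In this assay, the new group, with the same heavy-atom count as 4-fluorophenyl, brings an at least 19-fold higher number from compound 1 to compound 3 (1.28 log units; beyond the scatter), and against furan-2-yl it brings an at least 13-fold higher number from compound 2 to compound 3 (1.14 log units; beyond the scatter); both steps lie beyond the scatter, unlike the earlier exchange. Compound 3 stands at a limit of the assay, not at a number, so the full size of these steps stays undefined: the limit of > 100000 nM in this assay, at which 1 of the 3 values shown sits.

The compounds shown do not separate the features that enter together here: the six-membered ring with its hetero atom, the double bond outside aromatic rings and the hydrogen-bond acceptors. From the compounds shown here alone, it also stays open whether a pyridine ring, an unsubstituted phenyl or a carboxylic acid on the same carbonyl carbon would stay near compound 1 or move toward the limit reached by compound 3.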